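This account rests on a few compounds, and the source may have more. Where it says the series, first, only, none or still open, it means among the compounds named here.

Measured so far:
- Compound 1, `Clc1ccc(-n2cc(CSc3nc4ccccc4s3)nn2)cc1`: 50%
- Compound 2, `CCOc1ccc(-n2cc(CSc3nc4ccccc4s3)nn2)cc1`: 38.3%

In a functional assay on the whole organism (strain Albino Wistar) for inhibition, with Rattus norvegicus as the target, read by paw edema, with stated times of 1 h and 3 h, at a dose of 10 mg/kg by the oral route (on this read-out lower numbers stand for less inhibition and higher numbers for more inhibition at the one dose given (going by the name of the read-out)), compound 1 gives 50% and stands highest of the two numbers shown; compound 2, the nearest, sits lower by a number 11.7 percentage points lower from compound 1 to compound 2 (beyond the scatter), a modest step beyond the scatter.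

Compound 3, `c1cncc(-n2cc(CSc3nc4ccccc4s3)nn2)c1`, is reached from compound 1 by a single change: pyridin-3-yl in place of 4-chlorophenyl on an aromatic nitrogen. For the measured compounds named here, the one measured step, from compound 1 to compound 2, also alters this part of the molecule, replacing chloro with ethoxy on the aromatic carbon, and it lowered the read-out by a number 11.7 percentage points lower from compound 1 to compound 2 (beyond the scatter). Going by the values given here, no measured pair exchanges the whole 4-chlorophenyl for pyridin-3-yl, so that single step is the only guide. A similar modest drop, or no change beyond the scatter, is therefore expected. Compound 3 is estimated at 40%, with a range from 25% to 55%, an expected step of a number 10 percentage points lower from compound 1 to compound 3 (within the scatter).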

Compound 3, a percentage reported as inhibition, in the whole organism at one dose (the size of the read-out at that dose, not a potency): 64%
The estimate for compound 3 lay 24 percentage points below the measured number; measured number above the stated range.
By their numbers in this assay, from the lowest: compound 2; then compound 1; then compound 3.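

In this assay, replacing the whole ring on the aromatic nitrogen gives a number 14 percentage points higher from compound 1 to compound 3 (beyond the scatter), so changes at this position can raise the read-out as well as lower it, which the earlier step alone did not show. This single change removes the chlorine and also brings in a ring with a hetero atom and one hydrogen-bond acceptor, so this pair cannot separate the contribution of each. No measurement here explains the rise.

The compounds shown leave open whether the higher number goes with the ring nitrogen or with the loss of the chloro group, a question that a plain phenyl on the same nitrogen could help to settle. They also leave open how pyridin-4-yl, or a phenyl ring bearing an amine, would read in this assay.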